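The source may report more compounds than this note shows. Statements on the series, on what has been measured and on what is new or still open speak of the compounds shown alone.

Measured so far:
- compound 1, `O=S(=O)(NCCCNc1nccc(-c2c(-c3cccc(F)c3)nc3sccn23)n1)c1ccc(Cl)cc1`: 5900 nM
- compound 2, `Cc1ccc(C(=O)NCCNc2nccc(-c3c(-c4cccc(F)c4)nc4sccn34)n2)cc1`: 5880 nM
- compound 3, `Cc1ccc(S(=O)(=O)NCCNc2nccc(-c3c(-c4cccc(F)c4)nc4sccn34)n2)cc1`: 15400 nM

These three compounds share a core and differ only in the side chain that hangs from a nitrogen on an aromatic ring. In a functional assay on A-375 cells (Homo sapiens) for cytotoxicity, read by MTT assay (a lower number here means a stronger inhibitor, a higher number a weaker inhibitor), compound 3 gives the highest of the three numbers: a 2.6-fold higher number from compound 1 to compound 3 (0.42 log units; beyond the scatter) and a 2.6-fold higher number from compound 2 to compound 3 (0.42 log units; beyond the scatter), both modest steps, while a 1.0-fold lower number from compound 1 to compound 2 (0.00 log units; within the scatter).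

Compound 4, `O=S(=O)(NCCCNc1nccc(-c2c(-c3cccc(F)c3)nc3sccn23)n1)c1ccc(F)cc1`, has not yet been measured. It differs from compound 3 in one place:

(((4-fluorophenyl)sulfonyl)amino)methyl in place of ((4-methylphenyl)sulfonyl)amino on a saturated chain carbon, two bonds along the chain from a nitrogen on an aromatic ring

This change brings back the longer chain and the sulfonyl-bearing ring pattern of compound 1, with a fluorine in place of the chlorine. For the measured compounds named here, the step that bears on it most directly is the one from compound 1 to compound 3, a modest rise, which compound 4 is expected to roughly undo. Compound 4 is therefore expected to land near compound 1, giving an expected 2.8-fold lower number from compound 3 to compound 4 (0.45 log units; beyond the scatter). The estimate for compound 4 in this assay is 5500 nM, with a range from 2500 nM to 12000 nM.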

Compound 4, half-maximal inhibitory concentration: 14500 nM
Compound 4: middle estimate off by 2.6-fold (0.42 log units), on the low side, and the stated range ends below it.
By their numbers in this assay, from the lowest: compounds 2 and 1 (each within the scatter of the next); then compounds 4 and 3 (each within the scatter of the next).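

In this assay, for the compounds shown here, the single change of fluoro in place of chloro on an aromatic carbon gives a 2.5-fold higher number from compound 1 to compound 4 (0.39 log units; beyond the scatter), so the chain and sulfonyl group shared with compound 1 do not alone set the number. The two other comparisons give a 1.1-fold lower number from compound 3 to compound 4 (0.03 log units; within the scatter) and a 2.5-fold higher number from compound 2 to compound 4 (0.39 log units; beyond the scatter), placing the fluoro compound with the methyl-bearing sulfonyl compound rather than with the carbonyl compound. Nothing measured here explains why this halogen swap shifts the number.

The compounds shown leave open whether bromo or a methoxy group in place of the chloro would give a number like that of compound 1 or that of compound 4. They also leave open how a still longer chain carrying the (4-fluorophenyl)sulfonyl group would behave.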